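Removing a Fluorine from the Trifluoromethoxyphenyl Ether

The compounds below may be only part of what the source reports. "The series", "measured", "known", "first", "only" and "open" are said of these compounds alone.

Compound 3 `COc1cc2[nH]c(C)c(-c3ccc(Oc4ccc(F)c(OC(F)(F)F)c4)cc3)c(=O)c2cc1Cl` was examined in an ADME assay on HepG2 cells (Homo sapiens) for cytotoxicity, read by resazurin assay, with a stated time of 24 h; a lower number here means a stronger inhibitor, a higher number a weaker inhibitor. In this assay compound 3 gives > 10000 nM, which is a limit of the assay rather than a number. Compound 1 `COc1ccc2c(=O)c(-c3ccc(Oc4ccc(OC(F)(F)F)cc4)cc3)c(C)[nH]c2c1` is in the same situation, since in this assay compound 1 gives > 10000 nM, again a limit. Compound 2 `CCCCCCCc1c(C)[nH]c2cc(OC)c(Cl)cc2c1=O` has "not determined" (no result reported) in this assay. Compound 3 therefore sits at the limit shared by most of the shown values (the limit of > 10000 nM in this assay, at which 2 of the 3 values shown sit), and no step between two measured compounds is available for comparison.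

Compound 4 `COc1cc2[nH]c(C)c(-c3ccc(Oc4cccc(OC(F)(F)F)c4)cc3)c(=O)c2cc1Cl` has not yet been measured. It differs from compound 3 by hydrogen in place of fluoro on an aromatic carbon; the fluoro that leaves sits ortho to a trifluoromethoxy group and para to a large group. Among the measured compounds shown here, with the only related measurements being limits, the expected step is a step that the limit leaves unreadable from compound 3 to compound 4, none beyond the scatter. Compound 4 is therefore expected to give about 15000 nM, between 8000 nM and 40000 nM, and most likely this assay will again report only a limit.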

Compound 4, half-maximal inhibitory concentration: > 10000 nM
Compound 4: a limit, no number (the forecaster's own chance of this, stated with the estimate: 85%); the middle value is on the limit's open side.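

In this assay, compound 3 and compound 4 each give only a limit, so no step between them can be read: the limit of > 10000 nM in this assay, at which 3 of the 4 values shown sit.

The compounds shown leave open whether hydrogen in place of fluoro on this aromatic carbon changes the result in this assay at all.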